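Carbonyl aryl exchange in the enone series: compound 3

The source may hold more compounds than are shown below. What is called first, only, known or untested is meant among the compounds shown, and "the series" means these compounds.

Compound 1 `COc1ccc(-c2cc3ccccc3nc2/C=C/C(=O)c2ccccc2)cc1` and compound 2 `COc1ccc(-c2cc3ccccc3nc2/C=C/C(=O)c2ccc[nH]2)cc1` share one core and differ only in the group on the carbonyl carbon. In a functional assay on NCI-H460 cells (Homo sapiens) for antiproliferative activity, read by XTT assay, with a stated time of 72 h (on this read-out lower numbers stand for stronger inhibition and higher numbers for weaker inhibition), compound 1 gives 6670 nM. Compound 2 in this assay gives > 10000 nM, which is a limit of the assay and not a number. The step of an at least 1.4-fold higher number from compound 1 to compound 2 (0.17 log units; that floor lies within the scatter) rests on that limit (the limit of > 10000 nM in this assay, at which 1 of the 2 values shown sits), so compound 2 stands at the edge of what this assay reports, with no number of its own. Compound 3 `COc1ccc(-c2cc3ccccc3nc2/C=C/C(=O)c2c[nH]c3ccccc23)cc1` carries the change (1H-indol-3-yl in place of 1H-pyrrol-2-yl on a carbonyl carbon). No measured step covers this exchange; the single step shown, from phenyl to 1H-pyrrol-2-yl on the same carbonyl carbon, is the only point of comparison, and it left compound 2 at the limit. The step of an at least 1.2-fold lower number from compound 2 to compound 3 (0.09 log units; that floor lies within the scatter) is expected to be small, with a return toward the number of compound 1 not excluded and a value again at the limit about as likely. The estimate for compound 3 in this assay is 8000 nM, within 2500 nM to 25000 nM.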

Compound 3, half-maximal inhibitory concentration: 8010 nM
The estimate for compound 3 lay 1.0-fold (0.00 log units) below the measured number; low and high end bracket the measured number.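

In this assay compound 3, with 1H-indol-3-yl on the carbonyl carbon, gives 8010 nM, so a group with one five-membered and one six-membered aromatic ring at this position still returns a number of its own. The step of a 1.2-fold higher number from compound 1 to compound 3 (0.08 log units; within the scatter) means that phenyl and 1H-indol-3-yl cannot be told apart at this position, and the larger group brings no measurable change from the value of compound 1. The step of an at least 1.2-fold lower number from compound 2 to compound 3 (0.09 log units; that floor lies within the scatter) starts from a limit and not a number, so it gives a floor only: the limit of > 10000 nM in this assay, at which 1 of the 3 values shown sits.

Within the data shown here, whether 1H-pyrrol-2-yl truly differs from the other two groups stays open, since the only reading for it is a limit, and three compounds give no trend with the size of the group. As far as these compounds go, how an aryl group carrying an amine or a carboxylic acid on the same carbonyl carbon would compare in this assay also stays open.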